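A few compounds are considered here, and "the series" means these few. Any claim that something is new, unique, unknown or untested is made for them only; others in the source may bear on it.

Measured so far:
compound 1, `CCOCCN(C[C@@H](O)CN1CCCC2(CCN(c3ncnc4[nH]cc(C)c34)CC2)C1)S(=O)(=O)c1c(C)cccc1C`, 1200 nM
compound 2, `Cc1cccc(C)c1S(=O)(=O)NC[C@@H](O)CN1CCC[C@@]2(CCN(c3ncnc(N)c3C3CC3)C2)C1`, 900 nM

Both compounds were run in an assay on LNCaP cells for inhibition of RAC-alpha serine/threonine-protein kinase (Homo sapiens); a higher number here means a weaker inhibitor, a lower number a stronger inhibitor. Compound 1 gives 1200 nM, and compound 2 gives 900 nM in this assay. The two values sit within the usual scatter of each other, so neither compound is distinguished from the other on these numbers, and since the two structures differ in more than one place no single step can be read from them.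

Compound 3, `Nc1ncnc(N2CC[C@@]3(CCCN(C[C@H](O)CNS(=O)(=O)c4ccccc4F)C3)C2)c1C1CC1`, is not yet measured in this assay. It differs from compound 2 in one place: 2-fluorophenyl in place of 2,6-dimethylphenyl on a sulfonyl sulfur. Among the measured compounds shown here, no measured pair shows the effect of such a swap at the sulfonyl sulfur, so the expectation rests only on the value of compound 2 and on the modest size of the change. The step from compound 2 to compound 3 is expected to be small, a 1.3-fold higher number from compound 2 to compound 3 (0.12 log units; within the scatter), and may well fall within the scatter in either direction. For compound 3 the estimate in this assay is 1200 nM, with a range from 400 nM to 3500 nM.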

Compound 3, half-maximal inhibitory concentration: 14000 nM
The estimate for compound 3 lay 12-fold (1.07 log units) below the measured number; the measured number lies above the stated range.
By their numbers in this assay, from the lowest: compounds 2 and 1 (each within the scatter of the next); then compound 3.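

Among the compounds shown here, the aryl group on the sulfonyl sulfur is not a silent position in this assay: 2-fluorophenyl in place of 2,6-dimethylphenyl gives a 16-fold higher number from compound 2 to compound 3 (1.19 log units; beyond the scatter) and lies beyond the scatter, the first single change that can be read. Both groups hold one six-membered aromatic ring of carbon only, and neither carries a hydrogen-bond donor, a hydrogen-bond acceptor or a net charge, so a swap that leaves these counted features alike is still enough for a large step. No measurement bears on the cause of this step.

The compounds shown leave open whether the step follows from the loss of the two methyl groups or from the entry of fluorine, a question that phenyl, 2-methylphenyl and 2,6-difluorophenyl on the sulfonyl sulfur would help to separate. Also open, from the compounds shown here alone, are whether a non-aromatic group such as cyclohexyl is tolerated on the sulfonyl sulfur, and whether the same swap gives a step of similar size on the core of compound 1.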